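The source may report more compounds than this note shows. Statements on the series, on what has been measured and on what is new or still open speak of the compounds shown alone.

Compound 3 `O=C1c2c[n+]([O-])c3ccccc3c2C(=O)c2c1c1ccccc1n2CCCCN1CCNCC1` gives the highest number of the three compounds measured in a functional assay on A-375 cells (Homo sapiens) for cytotoxicity, read by MTT assay, with a stated time of 72 h; on this read-out higher numbers stand for weaker inhibition and lower numbers for stronger inhibition: compound 3 gives 460 nM, whereas compound 1 `O=C1c2c[n+]([O-])c3ccccc3c2C(=O)c2c1c1ccccc1n2Cc1cn(C[C@@H](O)CO)nn1` gives 140 nM and compound 2 `O=C1c2c[n+]([O-])c3ccccc3c2C(=O)c2c1c1ccccc1n2Cc1cn([C@@H]2C[C@H](O)[C@@H](CO)O2)nn1` gives 20 nM. The step of a 3.3-fold higher number from compound 1 to compound 3 (0.52 log units; beyond the scatter) and the step of a 7.0-fold lower number from compound 1 to compound 2 (0.85 log units; beyond the scatter) are the two changes seen so far, and both concern the group on the aromatic nitrogen side of the shared core rather than the end of a saturated chain.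

Compound 4 `CN(C)CCCCCn1c2c(c3ccccc31)C(=O)c1c[n+]([O-])c3ccccc3c1C2=O` differs from compound 3 by (dimethylamino)methyl in place of piperazin-1-yl on a saturated chain carbon, four bonds along the chain from an aromatic nitrogen. Going by the values given here, no measured step touches the same change: the nearest, in which compound 3 takes part, alters a different part of the chain. The chain end of compound 4 keeps one hydrogen-bond acceptor and loses the ring and the donor of the piperazin-1-yl group, so nothing in the data points to a shift in this assay in either direction. Compound 4 is therefore expected to stay near compound 3, with an estimated step of a 1.2-fold lower number from compound 3 to compound 4 (0.06 log units; within the scatter) that lies within the scatter, giving an expected value of 400 nM, somewhere between 150 nM and 1200 nM.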

Compound 4, half-maximal inhibitory concentration: 560 nM
Beside the measured number, compound 4's estimate is 1.4-fold (0.15 log units) below it, within the range that was stated.
By their numbers in this assay, from the lowest: compound 2; then compound 1; then compounds 3 and 4 (each within the scatter of the next).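

In this assay the exchange on the saturated chain carbon, four bonds along the chain from an aromatic nitrogen, gives a 1.2-fold higher number from compound 3 to compound 4 (0.09 log units; within the scatter) and so shows that the piperazin-1-yl ring and its hydrogen-bond donor can give way to (dimethylamino)methyl with no difference beyond the scatter. Replacing the triazole-bearing group of the earlier compound with 4-(dimethylamino)butyl gives a 4.0-fold higher number from compound 1 to compound 4 (0.60 log units; beyond the scatter) and thus moves the number in the same direction as the step to the piperazine-ended chain. No evidence is available to explain either result.

The compounds shown leave open whether a morpholine or a carboxylic acid at the chain end would also read alike. They also leave open how a shorter or longer chain carrying the same dimethylamino group would read.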